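The source may hold more compounds than are shown below. What is called first, only, known or untested is meant among the compounds shown, and "the series" means these compounds.

Measured so far in a functional assay on A549 cells (Homo sapiens) for inhibition, read by CCK-8 assay, with a stated time of 72 h, tested at 2 uM; on this read-out higher numbers stand for more inhibition of growth at the one concentration tested and lower numbers for less inhibition of growth:
- compound 1 `Nc1ccccc1NC(=O)/C=C/c1ccc(CSc2cccc(F)c2)cc1`: 50.7%
- compound 2 `Nc1ccccc1NC(=O)c1ccc(CSc2ccc(Br)cc2)cc1`: 33.2%

Compound 1 stands highest of the two at 50.7%. Compound 2 is lower at 33.2%, and this gap lies beyond the scatter. The two compounds differ in more than one place, so the gap says nothing about any single change.

The next compound is compound 3 `Nc1ccccc1NC(=O)/C=C/c1ccc(CSc2cccc3ccccc23)cc1`, which keeps the core of compound 1 and carries naphthalen-1-yl in place of 3-fluorophenyl on a sulfur. Neither group leaves any hydrogen-bond donor or acceptor in the count, and neither carries a net charge.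

Within the data shown here, no measured pair isolates a change at this place, so the data give no size for this swap. Among the measured compounds shown here, the only anchor is compound 1 at 50.7%. An estimated step of a number 3.7 percentage points lower from compound 1 to compound 3 (within the scatter) is expected in this assay, slightly downward and not beyond the scatter. The wide range reflects how little the data constrain this change. For compound 3 the expected value is 47%, with an estimated range of 29% to 65%.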

Compound 3, percent growth inhibition at one concentration: 59.3%
Compound 3: the middle estimate sits 12.3 percentage points below what was measured; measured number inside the range.
By their numbers in this assay, from the lowest: compound 2; then compounds 1 and 3 (each within the scatter of the next).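

In this assay, among these compounds, replacing 3-fluorophenyl with naphthalen-1-yl on a sulfur gives the first size for a change at this place (a number 8.6 percentage points higher from compound 1 to compound 3 (within the scatter)). The step lies within the scatter, so this position takes a group of 10 heavy atoms and two six-membered aromatic rings in place of one of 7 heavy atoms and a single ring, with no change in growth inhibition that the read-out can separate from scatter at the one concentration tested, and the fluorine is not needed to keep that level in this pair. No measured property at hand bears on this result.

Going by these compounds, both groups compared here are aromatic, built on carbon rings and free of hydrogen-bond donors, acceptors and net charge, so it stays open how the position responds to a saturated group such as cyclohexyl, or to an aryl ring carrying an amine or a carboxylic acid. On these data alone, it also stays open whether naphthalen-1-yl on the sulfur would give a similar result on the core of compound 2, which differs from compound 1 in more than one place.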